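This account rests on a few compounds, and the source may have more. Where it says the series, first, only, none or still open, it means among the compounds named here.

Of the compounds shown here, three built on one shared core have been tested in an ADME assay on SJ-G2 cells (Homo sapiens) for cytotoxicity, read by MTT assay, with a stated time of 72 h; on this read-out lower numbers stand for stronger inhibition of growth and higher numbers for weaker inhibition of growth. Compound 1 `CCCCNC(=O)C1C(C(=O)O)[C@@H]2CC[C@H]1O2` gives 10000 nM in this assay. Compound 2 `CCCCCCCCCCNC(=O)C1C(C(=O)O)[C@@H]2CC[C@H]1O2` gives 10000 nM in this assay. Compound 3 `CCc1ccccc1NC(=O)C1C(C(=O)O)[C@@H]2CC[C@H]1O2` gives 10000 nM in this assay. Among the compounds with values here, the one step between neighbours that differ in a single place, no change at the digits printed from compound 1 to compound 2 (within the scatter), shows that hexyl entering on the saturated chain carbon four bonds along the chain from the amide-type nitrogen left the result where it was. Compound 2 thus stands level with compound 1 and compound 3 at the digits shown, with no ordering among the three that the scatter would allow.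

Compound 4 `CCCNC(=O)C1C(C(=O)O)[C@@H]2CC[C@H]1O2` has not yet been measured. It differs from compound 2 by hydrogen in place of heptyl on a saturated chain carbon, three bonds along the chain from an amide-type nitrogen. Within the data shown here, only one measured step bears on this kind of change, the shortening or lengthening of the chain on the amide-type nitrogen, and that step, no change at the digits printed from compound 1 to compound 2 (within the scatter), was flat. Taking the chain away again, as the change to compound 4 does, is therefore expected to produce no change at the digits printed from compound 2 to compound 4 (within the scatter), which is to say no movement beyond the scatter. Compound 4 is accordingly estimated at 10000 nM, within a range from 5000 nM to 20000 nM.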

Compound 4, concentration for 50% growth inhibition: 10000 nM
Estimate against measurement, compound 4: no gap at the digits printed; the measured number falls inside the stated range.
By their numbers in this assay, from the lowest: compounds 1, 2, 3 and 4 (each within the scatter of the next).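

In this assay the chain on the amide-type nitrogen can now be read in the shortening direction as well, since hydrogen in place of heptyl gives one flat step (no change at the digits printed from compound 2 to compound 4 (within the scatter)) and hydrogen in place of methyl gives another (no change at the digits printed from compound 1 to compound 4 (within the scatter)). The earlier step showed only that hexyl entering on the chain left the number where it was, whereas these steps show that the result also holds when a chain part leaves, whether that part is as small as methyl or as long as heptyl, at the carbon three bonds along the chain from the nitrogen. No measurement shown here offers an explanation for this flat result.

All the compounds shown give the same number, so they do not reveal which kind of change, if any, would move this read-out. Still open, going by these compounds, is whether an amine or a hydroxyl group on the chain, or a methyl ester in place of the carboxylic acid on the shared core, would shift the result beyond the scatter.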